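The source may report more compounds than this note shows. Statements on the series, on what has been measured and on what is new or still open speak of the compounds shown alone.

In a functional assay on MKN-45 cells (Homo sapiens) for inhibition, read by CCK-8 assay, with a stated time of 24 h (a higher number here means a weaker inhibitor, a lower number a stronger inhibitor), compound 1 `Cc1cccc(-n2cc(-c3ccc(/C=C4\C(=O)Nc5ccccc54)cc3)nn2)c1` gives 4690 nM. Compound 3 `Cc1cccc(-n2cc(-c3ccc(/C=C4\C(=O)Nc5ccc(F)cc54)cc3)nn2)c1` gives 6810 nM, level with compound 1 within the scatter. Compound 2 `O=C1Nc2ccccc2/C1=C/c1ccc(-c2cn(-c3cccc(Cl)c3)nn2)cc1` reports only a limit, > 20000 nM. Compound 4 `O=C1Nc2ccc(F)cc2/C1=C/c1ccc(-c2cn(-c3ccc(F)cc3)nn2)cc1` differs from compound 3 by 4-fluorophenyl in place of 3-methylphenyl on an aromatic nitrogen, with 4-fluorophenyl in place of 3-methylphenyl on an aromatic nitrogen. For the measured compounds named here, two measured steps bear on this change. Fluoro in place of hydrogen on the shared core gave a 1.5-fold higher number from compound 1 to compound 3 (0.16 log units; within the scatter). Chloro in place of methyl on the aromatic ring carried by that nitrogen gave an at least 4.2-fold higher number from compound 1 to compound 2 (0.62 log units; beyond the scatter), a step resting on a limit, and on that step a somewhat higher number is expected for compound 4. The estimated change is a 1.5-fold higher number from compound 3 to compound 4 (0.17 log units; within the scatter). Compound 4 is expected at 10000 nM, with a range of 3000 nM to 25000 nM.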

Compound 4, half-maximal inhibitory concentration: > 20000 nM
Compound 4 was reported as a limit; the forecaster's own chance of this, stated with the estimate: 25%; at least 2.0-fold (0.30 log units) between middle value and limit.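

In this assay, 4-fluorophenyl in place of 3-methylphenyl on an aromatic nitrogen gives an at least 2.9-fold higher number from compound 3 to compound 4 (0.46 log units; beyond the scatter). Earlier, only compound 2 showed a change on this ring beyond the scatter, and that was on the core without fluoro; this step shows the same direction on the fluoro core of compound 3. The value of compound 4 is a limit, not a number: the limit of > 20000 nM in this assay, at which 2 of the 4 values shown sit.

Going by these compounds, how far compound 4 lies past that limit stays unknown. Also open, on these data alone, is whether an amine or a carboxylic acid on the ring carried by that nitrogen would give a measurable number.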